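The source may hold more compounds than are shown below. What is called first, only, known or untested is meant among the compounds shown, and "the series" means these compounds.

Compound 1 `CNC(=O)/C=C/c1ccncc1-c1ccc2cc[nH]c2c1` carries a methylcarbamoyl group on the ethenyl chain that hangs from its core. In an assay on a protein complex for inhibition of CDK8/Cyclin C (Homo sapiens), with a stated time of 1 h (a lower number here means a stronger inhibitor, a higher number a weaker inhibitor), compound 1 gives 18.6 nM. Among the measured compounds shown here, only one other compound in this set has a number to set beside it: compound 3 `COC(=O)/C=C/c1ccncc1-c1ccc2ccccc2c1`, in which a methyl ester replaces the amide and which also bears a different ring on the core. In this assay compound 3 gives 40.6 nM, a higher number than that of compound 1 by a margin beyond the scatter, so among the two numbers available compound 1 stands lowest. A third compound, compound 2 `COC1CN(C(=O)/C=C/c2ccncc2-c2ccc(F)cc2)C1`, has in this assay only "not determined" (no result reported), that is, no result, and nothing can be read from it.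

Compound 4 `O=C(O)/C=C/c1ccncc1-c1ccc2cc[nH]c2c1` is the next compound to be measured. It differs from compound 1 in one place only: hydroxy in place of methylamino on a carbonyl carbon, turning the amide into a carboxylic acid. For the measured compounds named here, no measured pair in this set isolates this exact change, so the expectation rests on the general picture. The amide of compound 1 and the ester of compound 3 already differ beyond the scatter, and a free acid is expected to move further still in the weaker direction. The step from compound 1 to compound 4 is estimated at a 4.8-fold higher number from compound 1 to compound 4 (0.68 log units; beyond the scatter). Compound 4 is therefore expected to give about 90 nM in this assay, within a range from 25 nM to 400 nM.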

Compound 4, half-maximal inhibitory concentration: 2.4 nM
For compound 4 the middle estimate is 38-fold (1.57 log units) above the measured one, outside the stated range (below it).
By their numbers in this assay, from the lowest: compound 4; then compound 1; then compound 3.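

Among the compounds shown here, replacing methylamino with hydroxy on a carbonyl carbon gives a 7.8-fold lower number from compound 1 to compound 4 (0.89 log units; beyond the scatter) in this assay and is the first change in this set made at one place alone. With the rest of the structure held constant, this step shows that the number responds clearly to what sits on this carbonyl carbon. It also shows that the methylcarbamoyl group is not needed for a low number here, since the carboxy group in its place gives the stronger inhibitor of this pair. Nothing measured here explains why the carboxylic acid outperforms the amide.

For the compounds shown here, the single pair cannot show whether the gain is specific to the carboxylic acid or whether other small groups on this carbonyl carbon would do as well. A primary amide, carrying a plain amino group, or a methyl ester on the core of compound 1 would help separate these possibilities, while a carboxylic acid on a different core, or one at the end of a longer chain, would test how far the gain extends beyond this one structure.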